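This account rests on a few compounds, and the source may have more. Where it says the series, first, only, none or still open, it means among the compounds named here.

Compound 1, `N#Cc1cccc(NC(=O)c2cc(C(F)(F)F)ccc2OCc2ccc(F)cc2)c1`, gives < 1000 nM in a physicochemical assay for solubility, measured as kinetic solubility (on this read-out lower numbers stand for lower solubility and higher numbers for higher solubility), a limit of the assay rather than a number. Compound 2, `O=C(Nc1ccnnc1)c1cc(N2CCC(F)CC2)ccc1OCc1ccccc1`, gives 20000 nM. Compound 3, `O=C(Nc1ccnnc1)c1cc(N2CCC(CO)CC2)ccc1OCc1ccccc1`, gives 323000 nM.

Compound 2 holds the lowest of the two numbers shown; one further value sits at the limit of < 1000 nM in this assay, at which 1 of the 3 values shown sits. Going by the values given here, the only measured step, a 16-fold higher number from compound 2 to compound 3 (1.21 log units; beyond the scatter), is the sole guide. Compound 4, `C[C@@H]1CN(c2ccc(OCc3ccccc3)c(C(=O)Nc3ccnnc3)c2)C[C@H](C)O1`, differs from compound 2 by 2,6-dimethylmorpholin-4-yl in place of 4-fluoropiperidin-1-yl on an aromatic carbon. The entering ring carries a second hydrogen-bond acceptor and no hydroxymethyl donor, and its resemblance to the measured step is loose. Compound 4 is expected to show a smaller rise in this assay, a 2.3-fold higher number from compound 2 to compound 4 (0.35 log units; beyond the scatter). Compound 4 is therefore estimated at 45000 nM, within a range of 12000 nM to 170000 nM.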

Compound 4, solubility: 29000 nM
The estimate for compound 4 lay 1.6-fold (0.19 log units) above the measured number; the measured number falls inside the stated range.
By their numbers in this assay, from the lowest: compounds 2 and 4 (each within the scatter of the next); then compound 3. At a limit, below all of these: compound 1.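

In this assay the exchange of 4-fluoropiperidin-1-yl for 2,6-dimethylmorpholin-4-yl on this aromatic carbon gives a 1.5-fold higher number from compound 2 to compound 4 (0.16 log units; within the scatter) and so separates these two compounds by no more than repeat measurements would. Set against the hydroxymethyl-bearing ring, the same 2,6-dimethylmorpholin-4-yl group gives an 11-fold lower number from compound 3 to compound 4 (1.05 log units; beyond the scatter) and leaves compound 3 alone at the top of the three compounds with numbers. No measurement shown speaks to the cause of these differences.

On these data alone, whether a free hydroxyl on the piperidine ring, a longer hydroxyalkyl chain or a carboxylic acid would match compound 3 stays open. So does whether an unsubstituted morpholine would behave like its dimethyl counterpart.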